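The source may hold more compounds than are shown below. What is called first, only, known or untested is meant among the compounds shown, and "the series" means these compounds.

Working notes on the series. The shared core is carried by compound 1 `Nc1nn(Cc2cn(-c3ccc(O)c([N+](=O)[O-])c3)nn2)c2nc(-c3ccccc3)cc(C(F)(F)F)c12` and compound 2 `Nc1nn(Cc2cn(CC(=O)Nc3c(F)cccc3F)nn2)c2nc(-c3ccccc3)cc(C(F)(F)F)c12`. In a functional assay on B16-F10 cells (Mus musculus) for cytotoxicity, read by MTT assay, with a stated time of 24 h (a higher number here means a weaker inhibitor, a lower number a stronger inhibitor), compound 1 gives 42.3 ug/mL; in the same assay compound 2 gives 41.6 ug/mL. For the measured compounds named here, compound 2 holds the lowest of the two numbers, but the only measured step, a 1.0-fold lower number from compound 1 to compound 2 (0.01 log units; within the scatter), lies within the scatter, so the two values cannot be ordered.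

Compound 3 `Nc1nn(Cc2cn(CC(=O)Nc3ccc(F)cc3Br)nn2)c2nc(-c3ccccc3)cc(C(F)(F)F)c12` differs from compound 2 in one place: 2-bromo-4-fluorophenyl in place of 2,6-difluorophenyl on an amide-type nitrogen. Going by the values given here, no measured step touches this position; the one step recorded, from compound 1 to compound 2, exchanged the whole group on the aromatic nitrogen and left the number unchanged within the scatter. A smaller exchange of one halogenated phenyl for another, further from the core, gives no reason in the data for a larger movement.

The estimate therefore is for no step beyond the scatter: a 1.0-fold lower number from compound 2 to compound 3 (0.02 log units; within the scatter). Compound 3 is expected to give 40 ug/mL in this assay, with a range from 20 ug/mL to 80 ug/mL.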

Compound 3, half-maximal inhibitory concentration: 98 ug/mL
Compound 3: the middle estimate sits 2.5-fold (0.39 log units) below what was measured; measured number above the stated range.
By their numbers in this assay, from the lowest: compounds 2 and 1 (each within the scatter of the next); then compound 3.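

In this assay, for the compounds shown here, the phenyl group on the amide-type nitrogen is the first place where the number moves: 2-bromo-4-fluorophenyl in place of 2,6-difluorophenyl gives a 2.4-fold higher number from compound 2 to compound 3 (0.37 log units; beyond the scatter), although the two groups match in heavy-atom count and in hydrogen-bond donors and acceptors. The ((2-bromo-4-fluorophenyl)carbamoyl)methyl group also stands apart from the 4-hydroxy-3-nitrophenyl group, with a 2.3-fold higher number from compound 1 to compound 3 (0.36 log units; beyond the scatter), whereas compound 2 carries the same carbamoylmethyl link and stays within the scatter of compound 1, so the link alone does not go with the higher number and the halogens on the phenyl ring do. Nothing in hand bears on why this exchange raises the number.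

The exchange brings in bromine and alters the fluorine substitution in a single move, and the compounds shown leave open which of the two goes with the weaker inhibition. A 2-bromophenyl or a 4-fluorophenyl group on the same nitrogen would separate the two, and a phenyl ring carrying an amine or a carboxylic acid would show how far this position responds beyond halogens.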